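The source may hold more compounds than are shown below. What is called first, only, known or untested is meant among the compounds shown, and "the series" means these compounds.

Within the data shown here, only two compounds have been measured so far in an ADME assay on HPC cells (Homo sapiens) for cytotoxicity, with a stated time of 24 h; on this read-out higher numbers stand for lower toxicity in this test and lower numbers for higher toxicity in this test. Compound 1 (`COc1cc(/C=C2\CCC/C(=C\c3ccccc3[N+](=O)[O-])C2=O)cc(OC)c1OC`) gives 35000 nM and compound 2 (`O=C1/C(=C/c2ccc(F)cc2)CCC/C1=C\c1cccc([N+](=O)[O-])c1`) gives 38000 nM. Compound 2 therefore stands level with compound 1, as the two numbers lie within the usual scatter of repeated measurements.

Compound 3 (`CN(C)c1ccc(/C=C2\CCC/C(=C\c3cccc([N+](=O)[O-])c3)C2=O)cc1`) has not yet been measured. It differs from compound 2 in one place: dimethylamino in place of fluoro on an aromatic carbon. In words, dimethylamino takes the place of fluoro on an aromatic carbon, so 4-fluorophenyl becomes 4-(dimethylamino)phenyl. Among the measured compounds shown here, no measured pair differs in only one place, so the data give no direct guide to this swap. Only a small move toward a lower number in this assay is expected, and it may not exceed the scatter. The estimated change is a 1.5-fold lower number from compound 2 to compound 3 (0.18 log units; within the scatter). For compound 3 the expected value is 25000 nM, with an estimated range of 8000 nM to 70000 nM.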

Compound 3, half-maximal cytotoxic concentration: > 400000 nM
Compound 3: a limit, no number; the forecaster's own chance of this, stated with the estimate: 10%; middle value at least 16-fold (1.20 log units) from the limit.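

In this assay, putting dimethylamino in place of fluoro on this aromatic carbon is far from a neutral swap: it gives an at least 10-fold higher number from compound 2 to compound 3 (1.02 log units; beyond the scatter). Among these compounds, this is the first sign that a change at this place, para to a large group, can move the read-out well beyond the scatter, something that compound 1 and compound 2 could not show, as they differ in more than one place. Compound 3 carries a limit of the assay and not a number, so the full size of the step stays unknown: the limit of > 400000 nM in this assay, at which 1 of the 3 values shown sits.

The compounds shown leave open whether a plain amino group or a morpholine at this place would move the number as far. They also leave open which feature of dimethylamino goes with the step, and whether the same swap would act alike on the core of compound 1.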